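A Methyl Group Tested on Two Different Cores

The source may hold more compounds than are shown below. What is called first, only, known or untested is meant among the compounds shown, and "the series" means these compounds.

Compound 1 `COn1c(-c2ccccc2)c(Br)c2cc(C#N)c(C#N)cc21`: in an assay on isolated protein for inhibition of Amine oxidase [flavin-containing] A (Homo sapiens), read by fluorescence and spectrophotometry, with a stated time of 20 min (a lower number here means a stronger inhibitor, a higher number a weaker inhibitor), compound 1 gives only a limit, > 100000 nM.
Compound 2 `COn1c(-c2ccc(C)cc2)c(Br)c2cc(C#N)c(C#N)cc21`: in this assay compound 2 likewise gives only a limit, > 100000 nM.
Compound 3 `O=C(O)c1cc2cc(-c3ccccc3)n(O)c2cc1C(=O)O`: in this assay compound 3 gives 23300 nM.

Two of the three compounds are therefore known only as limits, not as numbers. The change between the first two is methyl in place of hydrogen on an aromatic carbon, and the step it made is a step that the two limits leave unreadable from compound 1 to compound 2, because of the limit of > 100000 nM in this assay, at which 2 of the 3 values shown sit. Compound 4 `Cc1ccc(-c2cc3cc(C(=O)O)c(C(=O)O)cc3n2O)cc1` carries the very same change, (methyl in place of hydrogen on an aromatic carbon), on the core of compound 3 instead; the difference between the two cores is not broken down here. The earlier pair thus shows how the measurement can end in a limit, but says nothing about the size of the step.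

The expectation for compound 4 rests only on compound 3, which gives 23300 nM in this assay, so the step from it is expected to be small, a 1.2-fold lower number from compound 3 to compound 4 (0.07 log units; within the scatter). Compound 4 is accordingly estimated at 20000 nM, most likely between 5000 nM and 80000 nM.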

Compound 4, half-maximal inhibitory concentration: > 100000 nM
Compound 4 ended at the assay's limit (the forecaster's own chance of this, stated with the estimate: 25%); at least 5.0-fold (0.69 log units) between middle value and limit.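

On the core of compound 3, changing phenyl to 4-methylphenyl gave an at least 4.2-fold higher number from compound 3 to compound 4 (0.63 log units; beyond the scatter) in this assay, so on this core the added methyl goes with weaker inhibition. In this assay compound 4 gives > 100000 nM, which is a limit and not a number. This means the true size of the step remains unknown, and the same change on the core of compound 1 cannot be read, so the data cannot say whether the change has the same effect on both cores, because the measurements stop at the same limit: the limit of > 100000 nM in this assay, at which 3 of the 4 values shown sit.

What the compounds shown leave open is whether an amine or an ethyl group on the same aromatic carbon of compound 3 would keep the inhibition seen for compound 3 at 23300 nM or lose it as well. Going by these compounds, it also remains open whether any change to the core of compound 1 would bring it into the range where a number can be read.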